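Compound 3 to compound 4: a change of configuration alone

The source may hold more compounds than are shown below. What is called first, only, known or untested is meant among the compounds shown, and "the series" means these compounds.

Measured so far in a physicochemical assay for lipophilicity (on this read-out higher numbers stand for higher lipophilicity and lower numbers for lower lipophilicity), and still open:
- compound 1 `CN1CCN(c2cc(C(F)(F)F)ccc2[C@H]2CCOc3cc(S(=O)(=O)Nc4nccs4)ccc32)CC1` gives 2.1
- compound 2 `O=S(=O)(Nc1nccs1)c1ccc2c(c1)OCC[C@@H]2c1ccc(C(F)(F)F)cc1-c1ccc(F)cc1` gives 4.5
- compound 3 `O=S(=O)(Nc1nccs1)c1ccc2c(c1)OCC[C@H]2c1ccc(C(F)(F)F)cc1-c1ccc(F)nc1` gives "not determined" (no result reported)

For compound 3 the entry reads "not determined" (no result reported) and no number is available as a starting point. Compound 4 `O=S(=O)(Nc1nccs1)c1ccc2c(c1)OCC[C@@H]2c1ccc(C(F)(F)F)cc1-c1ccc(F)nc1` is related to it as follows: the two compounds have the same atoms and bonds and differ only in configuration as drawn: 1 of 1 stereo elements differ; a stereocentre at a saturated ring carbon is drawn S in compound 3 and R in compound 4 and a stereocentre at a saturated ring carbon is drawn S in compound 3 and R in compound 4.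

Within the data shown here, the only measured step is a number 2.40 log units higher from compound 1 to compound 2 (beyond the scatter) and it is large, but it puts 4-fluorophenyl in place of 4-methylpiperazin-1-yl and says nothing about configuration. Among the measured compounds shown here, no measured step therefore bears directly on this pair. From the change itself, no step beyond the scatter is expected in this assay in either direction. With no number for compound 3, the estimate is anchored on compound 2 at 4.5 and set somewhat lower, with a wide range.

Compound 4 is expected at 3.9 as an estimate, within a range of 3.3 to 4.5 in this assay for now.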

Compound 4, distribution coefficient: 3.2
Beside the measured number, compound 4's estimate is 0.70 log units above it, outside the stated range (below it).
By their numbers in this assay, from the lowest: compound 1; then compound 4; then compound 2.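

At the aromatic carbon that varies in this series, this assay responds to a change between two aryl groups as well as to the loss of 4-methylpiperazin-1-yl. Placing 6-fluoropyridin-3-yl in place of 4-fluorophenyl gives a number 1.30 log units lower from compound 2 to compound 4 (beyond the scatter) and so the aryl group itself matters here. Placing 6-fluoropyridin-3-yl in place of 4-methylpiperazin-1-yl gives a number 1.10 log units higher from compound 1 to compound 4 (beyond the scatter). Compound 4 therefore lies between compound 1 and compound 2, with both steps beyond the scatter.

Steps involving compound 3 cannot be read, so the effect of configuration on this read-out remains open, with only this established for the pair: the fact that compounds 3 and 4 differ only in the configuration as drawn. Also open, as far as these compounds go, is where a morpholin-4-yl group or a carboxylic acid at this aromatic carbon would fall in this assay.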